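The source may hold more compounds than are shown below. What is called first, only, known or untested is meant among the compounds shown, and "the series" means these compounds.

Measured compounds:
- compound 1, `CCCc1nc(C)c2c(C(C)C)nnc(O)n12`: > 48000 nM
- compound 2, `CCCc1nc(C)c2cnnc(O)n12`: 56800 nM

In a functional assay for inhibition, with Homo sapiens as the target (a lower number here means a stronger inhibitor, a higher number a weaker inhibitor), compound 1 gives > 48000 nM, which is a limit of the assay rather than a number. Compound 2 gives 56800 nM, the only real number shown, so its standing can be set against the value of compound 1 only. Among the compounds with values here, the single measured step, a step that the limit leaves unreadable from compound 1 to compound 2, cannot be read in size because of the limit of > 48000 nM in this assay, at which 1 of the 2 values shown sits.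

Compound 3 is `Cc1nc(C)n2c(O)nncc12`. Compared with compound 2 it shows (hydrogen in place of ethyl on a saturated chain carbon bound to an aromatic carbon). Within the data shown here, no measured step concerns a saturated chain carbon, and the one step available is unreadable, so nothing here points to a shift in either direction. The expected step of a 1.0-fold higher number from compound 2 to compound 3 (0.00 log units; within the scatter) is therefore no larger than the usual scatter. Compound 3 is estimated at 57000 nM in this assay, within a range from 25000 nM to 130000 nM.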

Compound 3, half-maximal inhibitory concentration: > 48000 nM
Compound 3: a limit, no number; the forecaster's own chance of this, stated with the estimate: 35%; the middle value does not contradict the limit.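

In this assay compound 3 gives > 48000 nM, which is a limit and not a number. The size of the change between compound 2 and compound 3 therefore cannot be read: the limit of > 48000 nM in this assay, at which 2 of the 3 values shown sit.

Going by these compounds, whether the isopropyl of compound 1 or the propyl of compound 2 matters for inhibition stays open, with compound 2 alone holding a real number.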